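Replacing the Amide with a Free Acid

The compounds below may be only part of what the source reports. "The series", "measured", "known", "first", "only" and "open" are said of these compounds alone.

Compound 1, `C=CC1=C(C(=O)NCCCCC)C(c2ccc(Cl)c(Cl)c2)OC1`, gives in a functional assay on HeLa cells (Homo sapiens) for cytotoxicity, read by MTT assay, with a stated time of 24 h (on this read-out higher numbers stand for weaker inhibition and lower numbers for stronger inhibition), the limit > 100000 nM.
Compound 2, `C=CC1=C(C(=O)NCC(C)C)C(c2ccc(Cl)c(Cl)c2)OC1`, gives in this assay 60100 nM.
Compound 3, `C=CC1=C(C(=O)NCc2ccccc2)C(c2ccc(Cl)c(Cl)c2)OC1`, gives in this assay the limit > 100000 nM.

Compound 3 thus sits at the limit of > 100000 nM in this assay, at which 2 of the 3 values shown sit, not at a number. Compound 4, `C=CC1=C(C(=O)O)C(c2ccc(Cl)c(Cl)c2)OC1`, differs from it by hydroxy in place of benzylamino on a carbonyl carbon. Going by the values given here, none of the measured steps touches the carbonyl carbon; they only swap groups on the nitrogen side, and they were small: an at least 1.6-fold lower number from compound 1 to compound 2 (0.22 log units; that floor lies within the scatter), an at least 1.6-fold higher number from compound 2 to compound 3 (0.22 log units; that floor lies within the scatter), while a step that the two limits leave unreadable from compound 1 to compound 3. With every measured change leaving the numbers near the limit, compound 4 is expected to stay there too, so the estimated step is a number no higher from compound 3 to compound 4 (the limit leaves the size open). Compound 4 is estimated at 100000 nM, between 30000 nM and 300000 nM.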

Compound 4, half-maximal inhibitory concentration: 10300 nM
For compound 4 the middle estimate is 9.7-fold (0.99 log units) above the measured one; measured number outside the range, below it.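

Unlike the swaps on the nitrogen side, replacing the whole amine part on the carbonyl carbon with hydroxy gives steps beyond the scatter in this assay: an at least 9.7-fold lower number from compound 3 to compound 4 (0.98 log units; beyond the scatter), a 5.8-fold lower number from compound 2 to compound 4 (0.77 log units; beyond the scatter) and an at least 9.7-fold lower number from compound 1 to compound 4 (0.98 log units; beyond the scatter). This makes compound 4, the free acid, the most potent of the four compounds. The steps from compound 1 and compound 3 are only floors, as each starts from a limit: the limit of > 100000 nM in this assay, at which 2 of the 4 values shown sit.

On these data alone, it remains open whether this gain requires the free acid itself or only the loss of the nitrogen substituents. A methyl ester or a primary amide on the same carbonyl carbon would help separate the two.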